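The source may report more compounds than this note shows. Statements on the series, on what has been measured and on what is new or still open speak of the compounds shown alone.

Compound 1 `Cc1cccc2sc(NC(=O)CCN3CCN(C(C)(C)C)CC3)nc12` gives 147 nM in an assay on membranes from brain for displacement of a labelled ligand from Sigma non-opioid intracellular receptor 1 (Cavia porcellus), read by scintillation counting, with a stated time of 120 min; a lower number here means a stronger inhibitor, a higher number a weaker inhibitor; compound 2 `CCCCCCN1CCN(CCC(=O)Nc2nc3c(C)cccc3s2)CC1` gives 238 nM in this assay.

Among the measured compounds shown here, compound 2 holds the higher of the two numbers, yet its only neighbour, compound 1, lies within the scatter: the exchange of the group on the ring amine nitrogen gave a 1.6-fold higher number from compound 1 to compound 2 (0.21 log units; within the scatter). Compound 3 `Cc1cccc2sc(NC(=O)CCN3CCN(CC4CCCO4)CC3)nc12` carries oxolan-2-yl in place of pentyl on a saturated chain carbon bound to an amine nitrogen in a ring. For the measured compounds named here, the single step that bears on this change, at the same place in the shared core, stayed inside the scatter, so no step beyond the scatter is expected in this assay. Compound 3 is therefore estimated at 200 nM, with a range from 80 nM to 500 nM. This expectation amounts to a 1.2-fold lower number from compound 2 to compound 3 (0.08 log units; within the scatter).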

Compound 3, inhibition constant: 109 nM
Beside the measured number, compound 3's estimate is 1.8-fold (0.26 log units) above it; the range from low to high includes it.
By their numbers in this assay, from the lowest: compounds 3, 1 and 2 (each within the scatter of the next, the first and the last beyond it).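

In this assay, among the compounds shown here, oxolan-2-yl in place of pentyl gave a 2.2-fold lower number from compound 2 to compound 3 (0.34 log units; beyond the scatter), the first step on this amine nitrogen substituent to pass the scatter, though only modestly. Against the branched tert-butyl group, (oxolan-2-yl)methyl gave a 1.3-fold lower number from compound 1 to compound 3 (0.13 log units; within the scatter), so these two groups cannot be told apart here. Nothing available accounts for either step.

The compounds shown do not separate the ring from its oxygen: cyclopentylmethyl and an open-chain methoxyethyl group would each test one alone. On these data alone, how far a basic amine or a carboxylic acid at this place would shift the number also stays open.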